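Phenyl in place of ethynyl on a shared core

The source may hold more compounds than are shown below. What is called first, only, known or untested is meant among the compounds shown, and "the series" means these compounds.

Of the compounds shown here, three of a shared core have been tested in a functional assay on HepG2 cells (Homo sapiens) for cytotoxicity, read by MTT assay, with a stated time of 48 h; a lower number here means a stronger inhibitor, a higher number a weaker inhibitor. Compound 1 `Cc1nnc(SCc2ccccc2)n1N1C(=O)c2ccccc2C1=O` gives > 200000 nM, a limit of the assay and not a number. Compound 2 `CCOC(=O)CSc1nnc(CC)n1N1C(=O)c2ccccc2C1=O` gives > 200000 nM, also a limit. Compound 3 `C#CCSc1nnc(-c2cc(OC)c(OC)c(OC)c2)n1N1C(=O)c2ccccc2C1=O` gives > 200000 nM, again only a limit, so its position among the numbers shown cannot be ranked; it sits at the limit of > 200000 nM in this assay, at which 3 of the 3 values shown sit. Compound 4 `COc1cc(-c2nnc(SCc3ccccc3)n2N2C(=O)c3ccccc3C2=O)cc(OC)c1OC` differs from compound 3 by phenyl in place of ethynyl on a saturated chain carbon bound to a sulfur, propargylsulfanyl becoming benzylsulfanyl. Going by the values given here, no measured pair shows this step. Compound 1 already carries benzylsulfanyl and gives > 200000 nM, a limit. The step from compound 3 to compound 4 is expected to be a step that the limit leaves unreadable from compound 3 to compound 4, none beyond the scatter. Compound 4 is expected to give 300000 nM, between 150000 nM and 1000000 nM, most likely reported as a limit.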

Compound 4, half-maximal inhibitory concentration: > 200000 nM
Compound 4: only a limit was reported; the forecaster's own chance of this, stated with the estimate: 85%; the middle value lies beyond the limit too.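

Compound 4 stands at the same limit as compound 3 and compound 1, so neither step to compound 4 can be read: the limit of > 200000 nM in this assay, at which 4 of the 4 values shown sit.

The compounds shown leave open whether any group on the shared core gives a measurable value in this assay.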